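The compounds below may be only part of what the source reports. "The series", "measured", "known", "first", "only" and "open" are said of these compounds alone.

Working notes on the series. Three compounds have numbers in a functional assay on the whole organism with Canis familiaris (Canis lupus familiaris) as the target, at a dose of 2 mg/kg by the intravenous route; on this read-out lower numbers stand for a weaker effect and higher numbers for a stronger effect at the one dose given. Compound 1 `Cc1nc2c(OCc3ccccc3)ccc(C)n2c1C` gives 13%. Compound 2 `Cc1nc2c(OCc3ccccc3F)cccn2c1N` gives 93%. Compound 3 `Cc1nc2c(OCc3ccccc3)cccn2c1NC=O` gives 3%, the lowest of the three; the number for compound 1 sits within the scatter of it, while the number for compound 2 lies far beyond the scatter above it. For the measured compounds named here, no pair of these three differs in one place only, so no step is known.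

Compound 4 `CCNc1c(C)nc2c(OCc3ccccc3)cccn12` has not been measured. It differs from compound 3 by ethyl in place of formyl on a nitrogen on an aromatic ring. Going by the values given here, with no measured step of this kind, a moderate rise in this assay is expected rather than none, the estimated step from compound 3 to compound 4 being a number 37 percentage points higher from compound 3 to compound 4 (beyond the scatter). Compound 4 is thus estimated at 40%, with a range from 5% to 85%.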

Compound 4, a percentage reported as inhibition, in the whole organism at one dose (the size of the read-out at that dose, not a potency): 32%
Beside the measured number, compound 4's estimate is 8 percentage points above it, and the stated range covers the measured number.
By their numbers in this assay, from the lowest: compounds 3 and 1 (each within the scatter of the next); then compound 4; then compound 2.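

Ethyl in place of formyl on a nitrogen on an aromatic ring gives the first step of the series in this assay that can be read, a number 29 percentage points higher from compound 3 to compound 4 (beyond the scatter) in this modest change. The group on this nitrogen therefore bears on the read-out, even though the two groups have the same count of heavy atoms. Nothing available accounts for this step. From the compounds shown here alone, what a methyl or a longer chain such as propyl on this nitrogen would give remains open. So does whether the step holds on other versions of the shared core.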